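This account rests on a few compounds, and the source may have more. Where it says the series, first, only, none or still open, it means among the compounds named here.

Within the data shown here, the three compounds measured so far share a core in which a six-membered aromatic ring of carbon only carries a triazene-linked amine on one side and a varying group on the other. Compound 1 `CCCCCCCCN(C)/N=N/c1ccc(C(N)=O)cc1` gives 2.84 in a functional assay on L1210 cells (Mus musculus) for antiproliferative activity; a lower number here means a less potent compound, a higher number a more potent compound, by a factor of ten per unit of this negative logarithm. Compound 2 `CN(/N=N/c1ccc(C(N)=O)cc1)c1cccs1` gives 2.9 in this assay. Compound 3 `CCCCN(C)/N=N/c1ccc(CCC(=O)OCC)cc1` gives 3.02 in this assay, the highest of the three numbers, though its gaps to compound 2 and to compound 1 both lie within the usual scatter, so no order among the three can be claimed.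

Compound 4 `CCCCN(C)/N=N/c1ccc(C(N)=O)cc1` differs from compound 3 in one place: carbamoyl in place of 2-(ethoxycarbonyl)ethyl on an aromatic carbon. Carbamoyl at this position is already present in compound 1, which gives 2.84, and in compound 2, which gives 2.9, and both numbers sit close to that of compound 3. Among the measured compounds shown here, no single step between measured compounds isolates this change, so the expected step of a number 0.12 log units lower from compound 3 to compound 4 (within the scatter) is small, slightly downward if anything, and not beyond the scatter. Compound 4 is therefore estimated at 2.9, within a range from 2.5 to 3.3.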

Compound 4, logarithm of the reciprocal of the active concentration, log(1/C): 3.47
Compound 4: middle estimate off by 0.57 log units, on the low side; the whole stated range lies below it.
By their numbers in this assay, from the lowest: compounds 1, 2 and 3 (each within the scatter of the next); then compound 4.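

In this assay, carbamoyl in place of 2-(ethoxycarbonyl)ethyl on the aromatic carbon gives a number 0.45 log units higher from compound 3 to compound 4 (beyond the scatter), so with butyl kept on the amine nitrogen, the group at this position does change the number beyond the scatter. With carbamoyl held fixed, the amine side matters too: butyl in place of thiophen-2-yl on that nitrogen gives a number 0.57 log units higher from compound 2 to compound 4 (beyond the scatter), and a shorter chain, hydrogen in place of butyl four bonds along the chain from the nitrogen, gives a number 0.63 log units higher from compound 1 to compound 4 (beyond the scatter). Nothing measured here accounts for these steps.

Still open, as far as these compounds go, is whether a carboxylic acid or a nitrile on the aromatic carbon would stand above or below carbamoyl. Also open, from the compounds shown here alone, is whether a propyl or hexyl chain on the amine nitrogen would stand above or below butyl.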